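The compounds below may be only part of what the source reports. "The series", "measured", "known", "first", "only" and "open" are said of these compounds alone.

Compound 1 `NCCSNC(=O)[C@@H](CCC(F)(F)F)N(Cc1ccc(-c2ncon2)cc1F)S(=O)(=O)c1ccc(Cl)cc1` and compound 2 `COC(=O)[C@@H](N)CSNC(=O)[C@@H](CCC(F)(F)F)N(Cc1ccc(-c2ncon2)cc1F)S(=O)(=O)c1ccc(Cl)cc1` share one core and differ at a single place. In a physicochemical assay for pharmacokinetics, at pH 1, tested at 100 ug/mL (on this read-out lower numbers stand for a shorter-lived compound and higher numbers for a longer-lived compound), compound 1 gives > 500 h, which is a limit of the assay rather than a number. In this assay compound 2 likewise gives > 500 h, again a limit and not a number. The step that the two limits leave unreadable from compound 1 to compound 2 therefore cannot be read in size, since both of its ends sit at the limit of > 500 h in this assay, at which 2 of the 2 values shown sit. Compound 2 thus stands at the limit together with compound 1, and nothing in the numbers shown places it higher or lower than that. Compound 3 `O=C(NSc1ccccc1)[C@@H](CCC(F)(F)F)N(Cc1ccc(-c2ncon2)cc1F)S(=O)(=O)c1ccc(Cl)cc1` takes the change (phenyl in place of 2-amino-2-(methoxycarbonyl)ethyl on a sulfur). No measured step touches this sulfur, and the one step that is shown yields no readable size. Going by the values given here, the only guide is that both measured compounds, carrying different groups on the sulfur, reach the limit. Compound 3 is therefore expected to move by about a number no higher from compound 2 to compound 3 (the limit leaves the size open), that is, by nothing clear in either direction. For compound 3 the estimate in this assay is 500 h, with a range from 150 h to 1500 h, and a limit rather than a number is the likelier report.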

Compound 3, half-life: > 500 h
Compound 3: a limit, no number; the forecaster's own chance of this, stated with the estimate: 70%; the middle value lies on the limit itself.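

In this assay compound 3 gives > 500 h as a limit and not a number. Its steps from compound 1 and from compound 2 therefore cannot be read in size, as all three compounds sit at one limit: the limit of > 500 h in this assay, at which 3 of the 3 values shown sit. On these data alone, what stays open is the actual half-life of each compound, and whether the groups on the sulfur differ at all.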